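The source may report more compounds than this note shows. Statements on the series, on what has been measured and on what is new or still open speak of the compounds shown alone.

Series notes on the four compounds.

Compound 1 `Cc1cc(S(=O)(=O)/N=C(\N)N/N=C/C#Cc2ccccc2)c(SCc2ccccc2C)cc1Cl` carries the first core. In a functional assay on HeLa cells (Homo sapiens) for antiproliferative activity, read by MTT assay, with a stated time of 72 h (on this read-out lower numbers stand for stronger inhibition and higher numbers for weaker inhibition), compound 1 gives 19000 nM. Compound 2 `C/C(C#Cc1ccccc1)=N\N/C(N)=N/S(=O)(=O)c1cc(C)c(Cl)cc1SCc1ccccc1C` differs from compound 1 by a group of 11 heavy atoms (10 carbon, 1 nitrogen; one six-membered aromatic ring of carbon only) in place of a group of 10 heavy atoms (9 carbon, 1 nitrogen; one six-membered aromatic ring of carbon only), on an amine nitrogen and in this assay compound 2 gives 270000 nM; the step is a 14-fold higher number from compound 1 to compound 2 (1.15 log units; beyond the scatter).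

Compound 3 `Cc1cc(S(=O)(=O)/N=C(\N)N/N=C/C#Cc2ccccc2)c(SCc2ccccc2Cl)cc1Cl` carries the second core. In this assay compound 3 gives 14000 nM; the step of a 1.4-fold lower number from compound 1 to compound 3 (0.13 log units; within the scatter) means compounds 1 and 3 cannot be told apart on this read-out. The two cores differ by chloro in place of methyl on an aromatic carbon.

Compound 4 `C/C(C#Cc1ccccc1)=N\N/C(N)=N/S(=O)(=O)c1cc(C)c(Cl)cc1SCc1ccccc1Cl` is not yet measured. It differs from compound 3 by a group of 11 heavy atoms (10 carbon, 1 nitrogen; one six-membered aromatic ring of carbon only) in place of a group of 10 heavy atoms (9 carbon, 1 nitrogen; one six-membered aromatic ring of carbon only), on an amine nitrogen. The place of this change is described in the same words as for the change from compound 1 to compound 2, so the change is the same one, made on the second core instead of the first. For the measured compounds named here, the only measured instance of it is the pair compound 1 to compound 2, and there is no further pair to show whether the size of the step depends on the core. The expectation therefore rests on that one pair: compound 4 is expected to sit a step of a 14-fold higher number from compound 3 to compound 4 (1.15 log units; beyond the scatter) from compound 3, set beside the measured step, because a 14-fold higher number from compound 1 to compound 2 (1.15 log units; beyond the scatter). Compound 4 is estimated at 200000 nM in this assay. The range for compound 4 is expected to run from 70000 nM to 550000 nM, kept wide since a single pair carries the whole expectation.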

Compound 4, half-maximal inhibitory concentration: 25000 nM
The estimate for compound 4 lay 8.0-fold (0.90 log units) above the measured number; the measured number lies below the stated range.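

On the second core, the group of 11 heavy atoms in place of the group of 10 heavy atoms, on an amine nitrogen, gives a 1.8-fold higher number from compound 3 to compound 4 (0.25 log units; within the scatter) in this assay, so the large step seen on the first core does not carry over in size and this change cannot be transferred between these two cores as a fixed step: the same change on two cores in this assay, a 14-fold higher number (1.15 log units; beyond the scatter) from compound 1 to compound 2 and a 1.8-fold higher number (0.25 log units; within the scatter) from compound 3 to compound 4, 8.0-fold (0.90 log units) apart, beyond the scatter of two such steps

Read the other way round, chloro in place of methyl on an aromatic carbon gives an 11-fold lower number from compound 2 to compound 4 (1.03 log units; beyond the scatter), a large step on this background but not on the other, so the two changes do not add independently in this set: the same change on two cores in this assay, a 1.4-fold lower number (0.13 log units; within the scatter) from compound 1 to compound 3 and an 11-fold lower number (1.03 log units; beyond the scatter) from compound 2 to compound 4, 8.0-fold (0.90 log units) apart, beyond the scatter of two such steps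

Both gaps come from the same four compounds and are one observation rather than two; they show that the size of the step depends on the core here, but not what underlies that dependence, nor whether it holds on any other core.

The compounds shown leave open how the step would run on a core carrying fluoro or methoxy in place of the chloro or methyl. Also open, from the compounds shown here alone, is whether the dependence persists when the phenyl ring at the end of the alkyne gives way to a pyridine or a cyclohexyl group.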